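Methyl to Trifluoromethyl on a Toll-like Receptor 8 Antagonist

The compounds below may be only part of what the source reports. "The series", "measured", "known", "first", "only" and "open" are said of these compounds alone.

Measured so far, in an assay on PBMC cells for antagonist activity at Toll-like receptor 8 (Homo sapiens), read by HTRF, with stated times of 30 min and 20 h; on this read-out lower numbers stand for stronger inhibition and higher numbers for weaker inhibition:
Compound 1 `Cc1cc(-c2ccc(=O)n(C)c2)cc2cn(C3CCNCC3)nc12` gives 320 nM.
Compound 2 `Cc1cc(-c2ccc(=O)n(C)c2F)cc2cn(C3CCNCC3)nc12` gives 13 nM.
Compound 3 `Cc1cc(-c2ccc(=O)n(C)c2Cl)cc2cn(C3CCNCC3)nc12` gives 30 nM.

Compound 2 stands lowest of the three: compound 3 is nearest, with a 2.3-fold higher number from compound 2 to compound 3 (0.36 log units; beyond the scatter), and compound 1 is furthest, with a 25-fold lower number from compound 1 to compound 2 (1.39 log units; beyond the scatter). Compound 4 `Cn1c(F)c(-c2cc(C(F)(F)F)c3nn(C4CCNCC4)cc3c2)ccc1=O` differs from compound 2 in one spot, (trifluoromethyl in place of methyl on an aromatic carbon). The known steps concern another part of the shared core, a hydrogen replaced by a halogen: a 25-fold lower number from compound 1 to compound 2 (1.39 log units; beyond the scatter) and an 11-fold lower number from compound 1 to compound 3 (1.03 log units; beyond the scatter). Among the measured compounds shown here, none of them touches the methyl, so no measured step bears directly on this change. The expectation in this assay is therefore a step no larger than the scatter, a 1.2-fold higher number from compound 2 to compound 4 (0.06 log units; within the scatter). Compound 4 is estimated at 15 nM, within 5 nM to 45 nM.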

Compound 4, half-maximal inhibitory concentration: 15 nM
For compound 4 middle estimate and measured number coincide at the digits printed; low and high end bracket the measured number.
By their numbers in this assay, from the lowest: compounds 2, 4 and 3 (each within the scatter of the next, the first and the last beyond it); then compound 1.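

In this assay, this is the first change shown at this aromatic carbon, and trifluoromethyl in place of methyl gives a 1.2-fold higher number from compound 2 to compound 4 (0.06 log units; within the scatter) with no shift beyond the scatter. The position therefore accepts a group of more heavy atoms without a measurable loss, unlike the hydrogen-to-halogen steps elsewhere on the core, which moved the number strongly. Nothing measured here explains this tolerance. Still open, from the compounds shown here alone, is whether a hydrogen, an amine or a longer chain would be tolerated here. Also open, going by these compounds, is whether trifluoromethyl behaves the same alongside chloro, as in compound 3.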